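Replacing a pyrazole with a fluorinated benzoate ester

The compounds below may be only part of what the source reports. "The series", "measured", "known", "first", "only" and "open" are said of these compounds alone.

Measured compounds:
- compound 1 `CC(c1cc2cccnc2cc1F)n1cnc2ncc(-c3cnn(C)c3)nc21`: 9 uL/min
- compound 2 `CC(c1c(F)cc2ncccc2c1F)n1cnc2ncc(-c3cnn(C)c3)nc21`: 11 uL/min

In an ADME assay on microsomes from liver (Homo sapiens) for metabolic stability, read by LC-MS, using NADPH, with stated times of 5 min and 30 min, tested at 1 uM (on this read-out lower numbers stand for slow clearance and higher numbers for fast clearance), compound 1 gives 9 uL/min, the lowest of the two numbers seen so far, and its nearest neighbour, compound 2, gives 11 uL/min in this assay. For the measured compounds named here, the only measured step joins these two: a 1.2-fold higher number from compound 1 to compound 2 (0.09 log units; within the scatter). The two values therefore show no separation in this assay.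

Compound 3 `COC(=O)c1ccc(-c2cnc3ncn(C(C)c4cc5cccnc5cc4F)c3n2)cc1F` has not yet been measured in this assay. It differs from compound 1 in one place: 3-fluoro-4-(methoxycarbonyl)phenyl in place of 1-methyl-1H-pyrazol-4-yl on an aromatic carbon. Going by the values given here, no measured step concerns this kind of change; the single step from compound 1 to compound 2 swaps fluoro for hydrogen and gives no guidance on replacing the 1-methyl-1H-pyrazol-4-yl group with a 3-fluoro-4-(methoxycarbonyl)phenyl group. The expectation for compound 3 therefore rests on the value of compound 1 alone, and is estimated as a 1.6-fold higher number from compound 1 to compound 3 (0.19 log units; within the scatter), a step that may or may not exceed the scatter. Compound 3 is expected to give about 14 uL/min in this assay, within a wide range from 5 uL/min to 40 uL/min.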

Compound 3, intrinsic clearance in a liver preparation (reported as CLH), per the amount of preparation that the assay uses: 73 uL/min
Compound 3: middle estimate off by 5.2-fold (0.72 log units), on the low side; measured number outside the range, above it.
By their numbers in this assay, from the lowest: compounds 1 and 2 (each within the scatter of the next); then compound 3.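

In this assay, placing 3-fluoro-4-(methoxycarbonyl)phenyl in place of 1-methyl-1H-pyrazol-4-yl on this aromatic carbon of the shared core gives an 8.1-fold higher number from compound 1 to compound 3 (0.91 log units; beyond the scatter). This is the first change shown to move the clearance read-out beyond the scatter, whereas the fluoro-for-hydrogen change elsewhere on the molecule gave only a 1.2-fold higher number from compound 1 to compound 2 (0.09 log units; within the scatter), so the number is shown to respond to what this position carries. No supporting data shown here explain the size of the step or tie it to any one feature of the entering group.

The single step swaps a five-membered aromatic ring with 2 hetero atoms for a six-membered aromatic ring of carbon only and adds both fluoro and methoxycarbonyl, so the compounds shown do not separate the contributions of these parts. Going by these compounds, it remains open how an unsubstituted phenyl, a phenyl carrying only fluoro, or a phenyl carrying a carboxylic acid or a primary amide in place of the methoxycarbonyl would read in this assay, and whether any of them would stay closer to compound 1.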